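Notes on a second chloro group in the series

This account rests on a few compounds, and the source may have more. Where it says the series, first, only, none or still open, it means among the compounds named here.

Three measured compounds share one core and differ only in the chlorine pattern on the ring it carries. For the measured compounds named here, compound 1 `COc1ccc(C(N)=O)cc1/C=C/c1cccc(Cl)c1` is the only one with a number: in an ADME assay on HCT-116 cells (Homo sapiens) for antiproliferative activity (on this read-out lower numbers stand for stronger inhibition and higher numbers for weaker inhibition), compound 1 gives 15000 nM. Compound 2 `COc1ccc(C(N)=O)cc1/C=C/c1ccccc1Cl` reaches only a limit of this assay, giving > 50000 nM. Compound 3 `COc1ccc(C(N)=O)cc1/C=C/c1ccc(Cl)cc1Cl` likewise stops at a limit, with > 50000 nM. How the cores of compound 1 and compound 2 differ is not broken down here; the two hold the same atoms joined differently.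

The change from compound 2 to compound 3 is chloro in place of hydrogen on an aromatic carbon. Its size is a step that the two limits leave unreadable from compound 2 to compound 3, because both ends sit at the limit of > 50000 nM in this assay, at which 2 of the 3 values shown sit.

Compound 4 `COc1ccc(C(N)=O)cc1/C=C/c1ccc(Cl)c(Cl)c1` is not yet measured. It differs from compound 1 by chloro in place of hydrogen on an aromatic carbon. This is the same kind of change as that from compound 2 to compound 3, not the same one: in compound 3 the entering chloro is meta to a chloro group, in compound 4 it is ortho to a chloro group. The measured step gives no anchor for size.

For compound 4 in this assay the expected step is a 1.3-fold higher number from compound 1 to compound 4 (0.12 log units; within the scatter), resting on compound 1 at 15000 nM. The parallel step from compound 2 to compound 3 stays unread and adds no anchor. Compound 4 is estimated at 20000 nM, expected between 7000 nM and 60000 nM, with a real chance that only a limit is returned.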

Compound 4, half-maximal inhibitory concentration: 11000 nM
Compound 4: middle estimate off by 1.8-fold (0.26 log units), on the high side, within the range that was stated.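

In this assay the entry of a second chloro group, ortho to a chloro group and para to a large group, gives a 1.4-fold lower number from compound 1 to compound 4 (0.13 log units; within the scatter), which is no readable shift on this core. As far as these compounds go, the parallel step on the other core cannot be read, because compound 2 and compound 3 both stop at a limit: the limit of > 50000 nM in this assay, at which 2 of the 4 values shown sit. The carrying of this change from one core to another therefore remains untested, since a single readable step on a single core shows neither that its size transfers nor that it fails to.

Still open, from the compounds shown here alone, is whether a group other than chloro at this place, such as a nitrile, an amine or a carboxylic acid, would give a number apart from those of compound 1 and compound 4. Every compound shown carries at least one chloro group on this ring, so the first chloro group has no step of its own here.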